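Anilino versus cyclohexylamino on the shared core

The source may hold more compounds than are shown below. What is called first, only, known or untested is meant among the compounds shown, and "the series" means these compounds.

Measured so far:
compound 1, `COc1cccc(NC2=CC(=O)c3nc4n(c3C2=O)[C@H]2OC[C@@H](O)[C@H]2OC4)c1`, > 4000 nM
compound 2, `CCOc1ccccc1NC1=CC(=O)c2c(nc3n2[C@H]2OC[C@@H](O)[C@H]2OC3)C1=O`, > 4000 nM

In a functional assay on MCF7 cells (Homo sapiens) for inhibition, read by sulforhodamine B assay (a higher number here means a weaker inhibitor, a lower number a stronger inhibitor), compound 1 gives only a limit, > 4000 nM. Compound 2 likewise gives only a limit in this assay, > 4000 nM. Both values sit at the limit of > 4000 nM in this assay, at which 2 of the 2 values shown sit, so compound 1 has no measured number to stand on. Compound 3, `O=C1C=C(NC2CCCCC2)C(=O)c2c1nc1n2[C@H]2OC[C@@H](O)[C@H]2OC1`, is not yet measured; it differs from compound 1 by cyclohexyl in place of 3-methoxyphenyl on an amine nitrogen. Within the data shown here, no measured step exists for such a change, so no direction beyond the scatter is expected from a step that the limit leaves unreadable from compound 1 to compound 3. Compound 3 is expected near 6000 nM, between 2000 nM and 20000 nM, most likely again a limit.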

Compound 3, half-maximal inhibitory concentration: > 8000 nM
Compound 3: only a limit was reported; the forecaster's own chance of this, stated with the estimate: 75%; middle value at least 1.3-fold (0.12 log units) from the limit.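

No step can be read between compound 1 and compound 3: both give only limits in this assay. The compounds shown leave open how (3-methoxyphenyl)amino and cyclohexylamino compare, and whether any group on that amine nitrogen gives a measurable value.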